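The source may hold more compounds than are shown below. What is called first, only, known or untested is meant among the compounds shown, and "the series" means these compounds.

Measured so far in an ADME assay (liver) for metabolic stability, with Liver microsome (Rattus norvegicus) as the target, using microsomes and NADPH, with a stated time of 30 min; on this read-out lower numbers stand for slow clearance and higher numbers for fast clearance
compound 1 `CC#C[C@H]1CN(S(=O)(=O)c2ccc(N)nc2)CCN1c1ccc(S(=O)(=NC)C(F)(F)F)cc1` gives 257 mL.min-1.g-1
compound 2 `CC#C[C@H]1CN(S(=O)(=O)c2ccc(N)nc2)CCN1c1ccc(S(=O)(=O)NCC2CC2)cc1` gives 213 mL.min-1.g-1
compound 3 `CC#CCC(O)(c1ccc(N2CCN(S(=O)(=O)c3ccc(N)nc3)C[C@@H]2C#CC)cc1)C(F)(F)F` gives 115 mL.min-1.g-1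

Compound 3 clears the scatter against only one of the other two (a 2.2-fold lower number from compound 1 to compound 3 (0.35 log units; beyond the scatter)) and stays within it against the remaining one (a 1.9-fold lower number from compound 2 to compound 3 (0.27 log units; within the scatter)). The first two compounds also lie within the scatter of each other (a 1.2-fold lower number from compound 1 to compound 2 (0.08 log units; within the scatter)).

Compound 4 `CC#C[C@H]1CN(S(=O)(=O)c2ccc(N)nc2)CCN1c1ccc(C(O)(CC#N)C(F)(F)F)cc1` differs from compound 3 at one place. The change is cyano in place of prop-1-yn-1-yl on a saturated chain carbon, two bonds along the chain from an aromatic carbon and an oxygen on a saturated carbon and it amounts to cyano in place of prop-1-yn-1-yl on a saturated chain carbon, two bonds along the chain from an aromatic carbon and an oxygen on a saturated carbon. Cut one bond further out, it reads but-2-yn-1-yl to cyanomethyl.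

Among the compounds with values here, no measured step touches this position. All three exchange the whole group on the aromatic carbon, so they serve only as a guide to size, and the widest of them is modest (a 2.2-fold lower number from compound 1 to compound 3 (0.35 log units; beyond the scatter)). Within the data shown here, no measured pair fixes the direction, so a slightly lower number is only a weak leaning. The expected move in this assay is small (a 1.4-fold lower number from compound 3 to compound 4 (0.13 log units; within the scatter)) and no step beyond the scatter is firmly expected. For compound 4 the estimate, with its range, is 85 mL.min-1.g-1 (35 mL.min-1.g-1 to 190 mL.min-1.g-1).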

Compound 4, intrinsic clearance in microsomes: 57 mL.min-1.g-1
Compound 4: the middle estimate sits 1.5-fold (0.17 log units) above what was measured, within the range that was stated.
By their numbers in this assay, from the lowest: compounds 4, 3, 2 and 1 (each within the scatter of the next, the first and the last beyond it).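

In this assay, the exchange of prop-1-yn-1-yl for cyano on a saturated chain carbon gives the first step read at this position itself, and it stays within the scatter (a 2.0-fold lower number from compound 3 to compound 4 (0.30 log units; within the scatter)), so this pair alone does not resolve the change from but-2-yn-1-yl to cyanomethyl as a real move. Exchanging the whole group on the aromatic carbon does give steps beyond the scatter from both sulfur-bearing compounds (a 3.7-fold lower number from compound 2 to compound 4 (0.57 log units; beyond the scatter)) (a 4.5-fold lower number from compound 1 to compound 4 (0.65 log units; beyond the scatter)), whereas the group of compound 3 lies beyond the scatter only against compound 1. No supporting data on the cause of these steps are available.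

On these data alone, whether a larger step in this read-out can be reached at this position remains open, for instance with a primary amine, a carboxylic acid or a longer chain ending in a nitrile. Within the data shown here, the single pair also leaves open whether cyano in place of prop-1-yn-1-yl would give a step of similar size on a different group at the aromatic carbon.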